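From a Cyclohexyl Ring to an Open Chain

The source may report more compounds than this note shows. Statements on the series, on what has been measured and on what is new or still open speak of the compounds shown alone.

In an ADME assay for permeability, using PAMPA, at pH 7.4 (a higher number here means that the compound crosses the layer faster, a lower number that the compound crosses the layer more slowly), compound 1 (`Cc1[nH]c2ccccc2c(=O)c1Cc1ccccc1`) gives 102 10^-6 cm/s and compound 2 (`COc1cc2[nH]c(C)c(C3CCCCC3)c(=O)c2cc1Cl`) gives 630 10^-6 cm/s as the higher of the two numbers, with a gap beyond the scatter. These two compounds differ in more than one place, so their gap cannot be tied to any single change.

Compound 3 (`C=C(CCCCC)c1c(C)[nH]c2cc(OC)c(Cl)cc2c1=O`) keeps the core of compound 2 and alters one group on an aromatic carbon (a group of 7 heavy atoms (7 carbon; no ring) in place of a group of 6 heavy atoms (6 carbon; one six-membered non-aromatic ring of carbon only), on an aromatic carbon) while everything else stays the same. The cyclohexyl ring is gone, and the new chain has no ring but carries a double bond outside aromatic rings. Both groups are made of carbon only and carry no net charge.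

For the measured compounds named here, no measured pair here shows what such a swap does, so the expectation rests on compound 2 at 630 10^-6 cm/s as its only close reference. The expected result is a 1.2-fold lower number from compound 2 to compound 3 (0.08 log units; within the scatter) in this assay and stays within the scatter, with no clear move in either direction. The estimate for compound 3 is 520 10^-6 cm/s with a range from 210 10^-6 cm/s to 1150 10^-6 cm/s expected for the measurement.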

Compound 3, apparent permeability in the ADME assay: 755 10^-6 cm/s
Compound 3: the middle estimate sits 1.5-fold (0.16 log units) below what was measured, and the stated range covers the measured number.
By their numbers in the ADME assay, from the lowest: compound 1; then compounds 2 and 3 (each within the scatter of the next).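

For the compounds shown here, this is the first comparison here that isolates one change, since compounds 1 and 2 differ in more than one place. In the ADME assay, the step shows a 1.2-fold higher number from compound 2 to compound 3 (0.08 log units; within the scatter), so replacing the cyclohexyl ring on this aromatic carbon with an open chain carrying a double bond leaves no readable change in how fast the compound crosses the layer. The same swap does separate the two compounds in a physicochemical assay for solubility, read by HPLC, at pH 7.4 (a lower number here means a less soluble compound, a higher number a more soluble compound), where compound 2 gives 5000 nM and compound 3 gives 2000 nM, and the open chain goes with a less soluble compound: the measured solubility of compound 2, 5000 nM, and of compound 3, 2000 nM, a 2.5-fold lower number (0.40 log units; beyond the scatter)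

The compounds shown do not separate the loss of the ring from the arrival of the double bond, so neither feature can be held responsible on its own for the step in solubility. They also leave open how this position would respond in both read-outs to a group that is not made of carbon alone, such as an amine or a carboxylic acid, or to a longer chain.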